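A Methyl Swap at the Edge of Cytotoxicity

The compounds below may be only part of what the source reports. "The series", "measured", "known", "first", "only" and "open" are said of these compounds alone.

In a functional assay on NCI-H460 cells (Homo sapiens) for cytotoxicity, read by MTT assay, with a stated time of 48 h (a lower number here means that less compound is tolerated, a higher number that more compound is tolerated), compound 1 `O=C(NO)N1CCN(C(=S)N/N=C/c2ccccc2O)CC1` gives > 100000 nM, which is a limit of the assay and not a number. Compound 2 `O=C(NO)N1CCN(C(=S)N/N=C/c2ccccc2Cl)CC1` gives > 100000 nM, and this too is only a limit. For the measured compounds named here, the one measured change is a step that the two limits leave unreadable from compound 1 to compound 2, so it offers no size to carry forward. All that can be drawn on is the limit of > 100000 nM in this assay, at which 2 of the 2 values shown sit.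

Compound 3 `Cc1ccc(/C=N/NC(=S)N2CCN(C(=O)NO)CC2)cc1` keeps the shared core but carries 4-methylphenyl in place of 2-chlorophenyl on a carbon with a double bond to nitrogen. Because of the limit of > 100000 nM in this assay, at which 2 of the 2 values shown sit, no step beyond the scatter is expected in this assay, and neither direction can be favoured. The expected change is a number no higher from compound 2 to compound 3 (the limit leaves the size open). Compound 3 is estimated at 100000 nM, with an expected range from 40000 nM to 250000 nM, and it may well be reported only as a limit.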

Compound 3, concentration lethal to 50% of the cells: > 100000 nM
Compound 3: no number, only a limit (the forecaster's own chance of this, stated with the estimate: 80%); the middle value lies on the limit itself.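

Compound 3, like compound 1 and compound 2, gives only a limit in this assay and not a number, and the steps among these three compounds cannot be read. From the compounds shown here alone, what stays open is how far apart the three compounds truly lie.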